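This account rests on a few compounds, and the source may have more. Where it says the series, first, only, none or still open, it means among the compounds named here.

Measured so far:
Compound 1 `O=C(NO)c1ccc(-c2cn([C@@H]3C[C@H](CO)N(Cc4ccccc4)C3)nn2)cc1`: 14%
Compound 2 `O=C(NO)c1ccc(-c2cn([C@@H]3C[C@H](C(=O)O)N(Cc4ccccc4)C3)nn2)cc1`: a limit of the assay, < 10%
Compound 3 `O=C(NO)c1cccc(-c2cn([C@@H]3C[C@H](C(=O)O)N(Cc4ccccc4)C3)nn2)c1`: a limit of the assay, < 10%

In an assay on Sf9 cells for inhibition of histone deacetylase 11 (Homo sapiens), read by fluorescence, tested at 0.5 uM (on this read-out lower numbers stand for less inhibition and higher numbers for more inhibition at the one concentration tested (going by the name of the read-out)), compound 1 gives 14%. For compound 2 only a limit is known, < 10%. For compound 3 the read-out is likewise a limit, < 10%; note (the limit of < 10% in this assay, at which 2 of the 3 values shown sit). The change hydroxymethyl in place of carboxy on a saturated ring carbon gave a number at least 4 percentage points higher from compound 2 to compound 1 (that floor lies within the scatter). The two cores differ by 3-(hydroxycarbamoyl)phenyl in place of 4-(hydroxycarbamoyl)phenyl on an aromatic carbon, and that step is a step that the two limits leave unreadable from compound 2 to compound 3.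

Compound 4 `O=C(NO)c1cccc(-c2cn([C@@H]3C[C@H](CO)N(Cc4ccccc4)C3)nn2)c1` carries the same change, (hydroxymethyl in place of carboxy on a saturated ring carbon), on the core of compound 3. Because compound 3 sits at a limit, the size of the step to compound 4 is not fixed by the data; the expected step of a number at least 2 percentage points higher from compound 3 to compound 4 (that floor lies within the scatter) is set beside a number at least 4 percentage points higher from compound 2 to compound 1 (that floor lies within the scatter) as a small one. The expected value for compound 4 in this assay is 12%, between 4% and 22%.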

Compound 4, a percentage reported as inhibition, at one concentration (the size of the read-out at that concentration, not a potency): < 10%
Compound 4 was reported as a limit; the forecaster's own chance of this, stated with the estimate: 40%; middle value at least 2 percentage points away from the limit.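

Compound 3 and compound 4 both stand at a limit in this assay, so no step between them can be read: the limit of < 10% in this assay, at which 3 of the 4 values shown sit.

On these data alone, whether hydroxymethyl in place of carboxy shifts the read-out at all on the core of compound 3 stays open.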